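Fluoro for methoxy on the hydroxyphenyl ring across two cores

A few compounds are considered here, and "the series" means these few. Any claim that something is new, unique, unknown or untested is made for them only; others in the source may bear on it.

Of the compounds shown here, three have been measured in a functional assay on MCF7 cells (Homo sapiens) for antiproliferative activity, read by sulforhodamine B assay, with a stated time of 48 h; on this read-out higher numbers stand for weaker inhibition and lower numbers for stronger inhibition. Compound 1 `COc1ccc(OC)c(/C=C/C(=O)C(=Cc2ccc(O)c(OC)c2)C(=O)/C=C/c2cc(OC)ccc2OC)c1` gives 400 nM. Compound 2 `COc1ccc(OC)c(/C=C/C(=O)C(=Cc2ccc(O)c(F)c2)C(=O)/C=C/c2cc(OC)ccc2OC)c1` differs from compound 1 by fluoro in place of methoxy on an aromatic carbon. In this assay compound 2 gives 460 nM. The step is a 1.2-fold higher number from compound 1 to compound 2 (0.06 log units; within the scatter). Compound 3 `COc1ccc(/C=C/C(=O)C(=Cc2ccc(O)c(OC)c2)C(=O)/C=C/c2ccc(OC)cc2OC)c(OC)c1` has a different core from compound 1; the two share the same atoms joined differently, and the difference between the two cores is not broken down here. In this assay compound 3 gives 2140 nM, the highest of the three numbers, beyond the scatter from both compound 1 and compound 2.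

Compound 4 `COc1ccc(/C=C/C(=O)C(=Cc2ccc(O)c(F)c2)C(=O)/C=C/c2ccc(OC)cc2OC)c(OC)c1` is not yet measured. It differs from compound 3 by fluoro in place of methoxy on an aromatic carbon, the same change that separates compound 1 from compound 2, on the same ring and at the same place. Within the pair on the first core the change left the number essentially unmoved, as a 1.2-fold higher number from compound 1 to compound 2 (0.06 log units; within the scatter) shows. Going by the values given here, the expectation for compound 4 is therefore a similarly small step from compound 3, estimated as a 1.2-fold higher number from compound 3 to compound 4 (0.07 log units; within the scatter), resting on the single measured instance of this change in compound 1 and compound 2 and on the value of compound 3 2140 nM as the starting point. One pair is a thin basis, and the core of compound 3 may respond differently, so the range is kept broad. Compound 4 is expected to give about 2500 nM in this assay, between 1300 nM and 5000 nM.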

Compound 4, half-maximal inhibitory concentration: 5450 nM
Beside the measured number, compound 4's estimate is 2.2-fold (0.34 log units) below it; the measured number lies above the stated range.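

In this assay, going by these compounds alone, 4-hydroxy-3-methoxyphenyl to 3-fluoro-4-hydroxyphenyl gives a 2.5-fold higher number from compound 3 to compound 4 (0.41 log units; beyond the scatter) on the core of compound 3, and set beside the same change on the core of compound 1, the two steps do not separate: the same change on two cores in this assay, a 1.2-fold higher number (0.06 log units; within the scatter) from compound 1 to compound 2 and a 2.5-fold higher number (0.41 log units; beyond the scatter) from compound 3 to compound 4, 2.2-fold (0.35 log units) apart, within the scatter of two such steps The working reading is that the change carries over between these two cores with no gap that can be claimed, although taken alone only the step on the core of compound 3 lies beyond the scatter. Within the data shown here, this does not show that the core leaves the change without influence, since there is only one pair on each core and a gap within the scatter can neither establish nor exclude a real difference, and it says nothing about any third core.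

Going by these compounds, only methoxy and fluoro appear at this place on the ring, so it remains open how chloro, an amine or a plain hydrogen there would read on either core. All four compounds also keep the hydroxy group on this ring, which leaves open how a methoxy group or an amine in its place would read, and whether the fluoro for methoxy change would then still carry between the cores.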